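Series notes: methyl to ethyl homologue, compound 4

A few compounds are considered here, and "the series" means these few. Any claim that something is new, unique, unknown or untested is made for them only; others in the source may bear on it.

Compound 1 `Cc1nnc(SCC(=O)c2ccc(Cl)cc2)n1N1C(=O)c2ccccc2C1=O` is the reference point of the set. In a functional assay on HepG2 cells (Homo sapiens) for cytotoxicity, read by MTT assay, with a stated time of 48 h (a lower number here means a stronger inhibitor, a higher number a weaker inhibitor), compound 1 gives > 200000 nM, which is a limit of the assay and not a number. Compound 2 `CSc1nnc(C)n1N1C(=O)c2ccccc2C1=O` gives > 200000 nM in this assay, again only a limit. Compound 3 `Cc1nnc(SCc2ccccc2Cl)n1N1C(=O)c2ccccc2C1=O` gives > 200000 nM in this assay, also a limit. Consequently the steps a step that the two limits leave unreadable from compound 1 to compound 2, a step that the two limits leave unreadable from compound 1 to compound 3 and a step that the two limits leave unreadable from compound 2 to compound 3 cannot be sized; all three values sit at the limit of > 200000 nM in this assay, at which 3 of the 3 values shown sit.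

Compound 4 `CCc1nnc(SCC(=O)c2ccc(Cl)cc2)n1N1C(=O)c2ccccc2C1=O` differs from compound 1 by methyl in place of hydrogen on a saturated chain carbon bound to an aromatic carbon. For the measured compounds named here, no measured step touches this position: the measured steps all concern the group on the saturated chain carbon bound to a sulfur, and none of them could be read. So no measured step bears on the change from compound 1 to compound 4, and no direction can be inferred from the series. Given that compound 1 sits at the limit of > 200000 nM in this assay, at which 3 of the 3 values shown sit, compound 4 is expected to remain at or near that limit, with a step that the limit leaves unreadable from compound 1 to compound 4 expected to be nothing beyond the scatter should a number be obtained. The estimate for compound 4 in this assay is 300000 nM, with a range from 120000 nM to 1000000 nM, and most likely only a limit would again be reported.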

Compound 4, half-maximal inhibitory concentration: > 200000 nM
Compound 4: a limit, no number; the forecaster's own chance of this, stated with the estimate: 85%; the middle value lies beyond the limit too.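

In this assay compound 4 gives > 200000 nM, a limit and not a number, so no new step can be read between compound 1 and compound 4: the limit of > 200000 nM in this assay, at which 4 of the 4 values shown sit.

The compounds shown leave open which change to the shared core, if any, would give a readable number in this assay.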